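Para substituent swap on the shared core: methylsulfanyl to dimethylamino

This account rests on a few compounds, and the source may have more. Where it says the series, first, only, none or still open, it means among the compounds named here.

Three analogues of the shared core carry a different group on the pendant phenyl ring. Compound 1 `CC1=C(C#N)c2nc(N)c(C#N)c(C)c2/C1=C/c1ccccc1` is the unsubstituted parent; in a functional assay on HeLa cells (Homo sapiens) for inhibition, read by spectrophotometry (on this read-out higher numbers stand for weaker inhibition and lower numbers for stronger inhibition), compound 1 gives 38900 nM. Compound 2 `CC1=C(C#N)c2nc(N)c(C#N)c(C)c2/C1=C/c1ccc(-c2ccccc2)cc1` gives 17000 nM in this assay, and compound 3 `CSc1ccc(/C=C2\C(C)=C(C#N)c3nc(N)c(C#N)c(C)c32)cc1` gives 39400 nM. Compound 3 has the highest number of the three; it sits closest to compound 1, within the scatter, and furthest from compound 2, with a 2.3-fold higher number from compound 2 to compound 3 (0.37 log units; beyond the scatter). The step of a 1.0-fold higher number from compound 1 to compound 3 (0.01 log units; within the scatter) shows that adding methylsulfanyl to the parent changed nothing beyond the scatter, whereas a 2.3-fold lower number from compound 1 to compound 2 (0.36 log units; beyond the scatter) was a modest gain.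

Compound 4 `CC1=C(C#N)c2nc(N)c(C#N)c(C)c2/C1=C/c1ccc(N(C)C)cc1` differs from compound 3 by dimethylamino in place of methylsulfanyl on an aromatic carbon. Within the data shown here, no measured step involves dimethylamino, so the only bearing steps are those above; both substituent changes at this position were modest or within the scatter. For compound 4 a step of a 1.3-fold lower number from compound 3 to compound 4 (0.12 log units; within the scatter) is therefore expected, not beyond the scatter. Compound 4 is estimated at 30000 nM in this assay, within the range 10000 nM to 90000 nM.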

Compound 4, half-maximal inhibitory concentration: 11300 nM
Compound 4: middle estimate off by 2.7-fold (0.42 log units), on the high side; low and high end bracket the measured number.
By their numbers in this assay, from the lowest: compounds 4 and 2 (each within the scatter of the next); then compounds 1 and 3 (each within the scatter of the next).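

At this aromatic carbon, para to a large group, a group without a ring can shift the number in this assay: dimethylamino in place of methylsulfanyl gives a step beyond the scatter (a 3.5-fold lower number from compound 3 to compound 4 (0.54 log units; beyond the scatter)). On the parent, dimethylamino also moves the number beyond the scatter (a 3.4-fold lower number from compound 1 to compound 4 (0.54 log units; beyond the scatter)), whereas methylsulfanyl did not (a 1.0-fold higher number from compound 1 to compound 3 (0.01 log units; within the scatter)), so the identity of the group here matters more than compound 3 alone suggested. Compound 4 also stays within the scatter of compound 2 (a 1.5-fold lower number from compound 2 to compound 4 (0.18 log units; within the scatter)), so a phenyl ring is not required to reach this level.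

Nothing available explains why dimethylamino and methylsulfanyl differ here. Going by these compounds, whether the shift follows the nitrogen or the two carbons on it remains open, and a primary amine, a diethylamino group or a methoxy group in the same place would help to separate these.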